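The compounds below may be only part of what the source reports. "The series", "measured", "known", "first", "only" and "open" are said of these compounds alone.

Measured so far:
compound 1 `CCNC(=O)OC[C@]1(O)CO[C@@H](n2cnc3c(N)ncnc32)[C@@H]1O`: in an assay on CHO cells for displacement of a labelled ligand from adenosine receptor A1 (Homo sapiens), tested at 10 uM (on this read-out lower numbers stand for less inhibition and higher numbers for more inhibition at the one concentration tested (going by the name of the read-out)), compound 1 gives 9%
compound 2 `COc1ccc(Cl)cc1CNc1ncnc2c1ncn2[C@@H]1OC[C@](O)(CO)[C@H]1O`: in this assay compound 2 gives 12%

Compound 2 stands beside compound 1 in this assay; the two values lie within the usual scatter of each other, so no ordering between them can be read. Compound 3 `OC[C@@]1(O)CO[C@@H](n2cnc3c(NCc4cccc(Cl)c4)ncnc32)[C@@H]1O` differs from compound 2 by hydrogen in place of methoxy on an aromatic carbon. Within the data shown here, no step between measured compounds is known, and both measured values sit low, so no change beyond the scatter is expected for this move: a number 2 percentage points lower from compound 2 to compound 3 (within the scatter). Compound 3 is expected to give about 10% in this assay, with a range of 0% to 22%.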

Compound 3, a percentage reported as inhibition, at one concentration (the size of the read-out at that concentration, not a potency): 10%
The estimate for compound 3 equals the measured number at the digits printed; the measured number falls inside the stated range.
By their numbers in this assay, from the lowest: compounds 1, 3 and 2 (each within the scatter of the next).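

In this assay, hydrogen in place of methoxy on the aromatic carbon ortho to a large group and para to a chloro group gives a number 2 percentage points lower from compound 2 to compound 3 (within the scatter). The 5-chloro-2-methoxyphenyl and 3-chlorophenyl forms therefore cannot be told apart at this low level of inhibition, so methoxy shows no measurable contribution at this position. No supporting data bear on this result.

Going by these compounds, whether an amine, a carboxylic acid or a longer alkoxy chain at this carbon would move the number beyond the scatter stays open. On these data alone, the part played by the chloro group also stays open.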